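Replacing chloro with trifluoromethyl: working notes on the series

A few compounds are considered here, and "the series" means these few. Any claim that something is new, unique, unknown or untested is made for them only; others in the source may bear on it.

compound 1 `CN1C/C(=C\c2ccc(C(F)(F)F)cc2)C(=O)/C(=C/c2cccc([N+](=O)[O-])c2)C1` gives 970 nM
compound 2 `CN1C/C(=C\c2ccc(F)cc2)C(=O)/C(=C/c2ccc(C#N)cc2)C1` gives 5030 nM
compound 3 `CN1C/C(=C\c2ccc(Cl)cc2)C(=O)/C(=C/c2ccc(C#N)cc2)C1` gives 3180 nM

All three values come from a functional assay on THP-1 cells (Homo sapiens) for cytotoxicity, read by MTT assay, with a stated time of 24 h; on this read-out lower numbers stand for stronger inhibition and higher numbers for weaker inhibition. In this set, compound 3 at 3180 nM lies within the scatter of compound 2 , and compound 1 lies lower than compound 3 , beyond the scatter.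

The next compound to be measured is compound 4 `CN1C/C(=C\c2ccc(C#N)cc2)C(=O)/C(=C/c2ccc(C(F)(F)F)cc2)C1`. It differs from compound 3 by trifluoromethyl in place of chloro on an aromatic carbon. Going by the values given here, no measured step covers this exchange directly. The closest one is a 1.6-fold lower number from compound 2 to compound 3 (0.20 log units; within the scatter), chloro in place of fluoro on an aromatic carbon, and it stays within the scatter. Compound 1 at 970 nM also carries trifluoromethyl, but its second aromatic substituent differs from that of compound 4 , so its value gives only weak support for a lower number. No step beyond the scatter is therefore expected in this assay, with at most a slight lean towards a lower number. The expected change is a 1.3-fold lower number from compound 3 to compound 4 (0.10 log units; within the scatter). For compound 4 the estimated value is 2500 nM, with an expected range from 1000 nM to 6000 nM.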

Compound 4, half-maximal inhibitory concentration: 1430 nM
Compound 4: the middle estimate sits 1.7-fold (0.24 log units) above what was measured, and the stated range covers the measured number.
By their numbers in this assay, from the lowest: compounds 1 and 4 (each within the scatter of the next); then compounds 3 and 2 (each within the scatter of the next).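

In this assay, this position on an aromatic carbon of a six-membered aromatic ring of carbon only, para to a large group, now shows a step beyond the scatter: a 2.2-fold lower number from compound 3 to compound 4 (0.35 log units; beyond the scatter), and the larger exchange gives a 3.5-fold lower number from compound 2 to compound 4 (0.55 log units; beyond the scatter), whereas a 1.6-fold lower number from compound 2 to compound 3 (0.20 log units; within the scatter) had stayed within it. Among the three groups compared here, fluoro and chloro therefore cannot be separated, and only trifluoromethyl moves the number clearly, though both steps remain modest and rest on a single pair each. With trifluoromethyl present, the other aromatic substituent makes no readable difference in this pair: a 1.5-fold higher number from compound 1 to compound 4 (0.17 log units; within the scatter), within the scatter, for 4-cyanophenyl in place of 3-nitrophenyl.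

Nothing at hand accounts for the step from chloro to trifluoromethyl. Still open, going by these compounds, is whether the trend extends to other groups at this position, such as an amine, a carboxylic acid or a longer chain, and whether the same exchange gives a similar step with 3-nitrophenyl as the other aromatic substituent.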